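The source may hold more compounds than are shown below. What is called first, only, known or untested is meant among the compounds shown, and "the series" means these compounds.

Compound 1 `C=CCCC(COCCCCCCCCCCCCCCCCCC)NC(C)=O` gives 8000 nM in an assay for inhibition of putative inactive group IIC secretory phospholipase A2 (Homo sapiens); a lower number here means a stronger inhibitor, a higher number a weaker inhibitor.
Compound 2 `CCCCCCCCCCCCCCCCCCOCC(CC[S+](C)[O-])NC(C)=O` gives 60000 nM in this assay.

For the measured compounds named here, of the two numbers so far, compound 2 stands at the higher end, with compound 1 as its only neighbour: the change from the butenyl group of compound 1 to the methylsulfinylethyl group of compound 2 brought a 7.5-fold higher number from compound 1 to compound 2 (0.88 log units; beyond the scatter). Compound 3 `CCCCCCCCCCCCCCCCCCOCC(COCC(F)(F)F)NC(C)=O` is the next member of the series. It differs from compound 2 in one place: a group of 6 heavy atoms (2 carbon, 1 oxygen, 3 fluorine; no ring) in place of a group of 4 heavy atoms (2 carbon, 1 oxygen, 1 sulfur; no ring), on a saturated chain carbon, two bonds along the chain from an amide-type nitrogen. Going by the values given here, only the step from compound 1 to compound 2 bears on this change, and it shows that replacing a hydrocarbon side chain with a heteroatom-bearing one can move the number by a modest amount. Since the trifluoroethoxy side chain sits between these two cases in character, compound 3 is expected to fall between compound 1 and compound 2, with a 3.0-fold lower number from compound 2 to compound 3 (0.48 log units; beyond the scatter) as the estimated step. Compound 3 is estimated at 20000 nM, within a range from 5000 nM to 70000 nM.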

Compound 3, half-maximal inhibitory concentration: 100000 nM
Compound 3: middle estimate off by 5.0-fold (0.70 log units), on the low side; measured number above the stated range.
By their numbers in this assay, from the lowest: compound 1; then compounds 2 and 3 (each within the scatter of the next).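

Placing 2,2,2-trifluoroethoxy on the saturated chain carbon, two bonds along the chain from an amide-type nitrogen, gives a 1.7-fold higher number from compound 2 to compound 3 (0.22 log units; within the scatter) when it enters in place of the group in compound 2, so these two side chains cannot be told apart here. The same group in place of allyl gives a 13-fold higher number from compound 1 to compound 3 (1.10 log units; beyond the scatter) and the step is large, so compound 1 stays clearly the strongest of the three, and both heteroatom-bearing side chains sit on the weak side of it. Nothing measured here explains why these side chains behave as they do.

From the compounds shown here alone, it remains open whether the low number of compound 1 depends on its hydrocarbon side chain, as a plain propyl or a longer chain at this position could show. Whether an amine or a carboxylic acid there would restore or further lower binding also remains unanswered.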